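Cytotoxicity of a fluoroquinolone-piperazine amide pair on macrophages

The compounds below may be only part of what the source reports. "The series", "measured", "known", "first", "only" and "open" are said of these compounds alone.

Compound 1, `O=C(O)c1cn(C2CC2)c2cc(N3CCN(C(=O)CN4CCN(c5ccccc5Cl)CC4)CC3)c(F)cc2c1=O`, was tested in an ADME assay on RAW264.7 cells (Mus musculus) for cytotoxicity, read by MTT assay, with a stated time of 72 h (a higher number here means a weaker inhibitor, a lower number a stronger inhibitor), where compound 1 gives 167000 nM. Its only companion in the set, compound 2, `O=C(O)c1cn(C2CC2)c2cc(N3CCN(C(=O)CN4CCN(C(c5ccccc5)c5ccccc5)CC4)CC3)c(F)cc2c1=O`, gives 96600 nM in this assay. The two numbers lie within the scatter of each other, so compound 1 stands at the higher of the two values without being separable from compound 2.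

Compound 3, `CCN1CCN(CC(=O)N2CCN(c3cc4c(cc3F)c(=O)c(C(=O)O)cn4C3CC3)CC2)CC1`, has not yet been measured. It differs from compound 1 in one place: ethyl in place of 2-chlorophenyl on an amine nitrogen in a ring. The shared core of compound 1 and compound 3 and the amide-linked piperazine are unchanged.

Among the measured compounds shown here, no step between measured compounds that would cover this kind of exchange is available, and the one comparison at hand, between compound 1 and compound 2, shows no difference beyond the scatter. On that basis the step from compound 1 to compound 3 is expected to be small, a 1.2-fold higher number from compound 1 to compound 3 (0.08 log units; within the scatter), leaning if anything toward a higher number. The estimate for compound 3 in this assay is therefore 200000 nM, within a range from 90000 nM to 450000 nM.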

Compound 3, half-maximal inhibitory concentration: 188000 nM
Estimate against measurement, compound 3: 1.1-fold (0.03 log units) above, and the stated range covers the measured number.
By their numbers in this assay, from the lowest: compounds 2, 1 and 3 (each within the scatter of the next).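

In this assay, among the compounds shown here, the exchange of 2-chlorophenyl for ethyl on an amine nitrogen in a ring gives a 1.1-fold higher number from compound 1 to compound 3 (0.05 log units; within the scatter), the first step at this position that can be read from a single exchange. It shows that this nitrogen can carry either a six-membered aromatic ring of carbon only, bearing a chlorine, or ethyl, with no ring at all, without the number moving beyond the scatter, so neither the aromatic ring nor the chlorine is needed for a reading of this size in compound 3. Nothing at hand gives a measured reason why the exchange leaves the number within the scatter.

The compounds shown leave open whether any group at this nitrogen can move the number beyond the scatter, for instance a chain ending in a carboxylic acid or a primary amine, or a longer chain such as n-octyl. They also leave open whether the unsubstituted piperazine amine, with a hydrogen in place of ethyl, would read the same in this assay.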